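Octyl amide series: carbamoyl in place of the hydroxyethyl group

A few compounds are considered here, and "the series" means these few. Any claim that something is new, unique, unknown or untested is made for them only; others in the source may bear on it.

For the measured compounds named here, compound 2 `CCCCCCCCN(C)C(=O)Cn1cc(Cc2cnc(=O)n(CCO)c2)c(=O)nc1SCc1ccc(F)cc1` gives 36% in a functional assay on a cell-free system (plasma, Oryctolagus cuniculus) for inhibition of platelet-activating factor acetylhydrolase (Homo sapiens), tested at 100 nM (a higher number here means more inhibition at the concentration tested (going by the name of the read-out), a lower number less inhibition), the higher of the two numbers known; compound 1 `CCCCCCCCN(C)C(=O)Cn1cc(Cc2cnc(=O)n(CC)c2)c(=O)nc1SCc1ccc(F)cc1` gives 5%. Going by the values given here, the only measured step, a number 31 percentage points higher from compound 1 to compound 2 (beyond the scatter), concerns a hydroxy in place of hydrogen. Compound 3 `CCCCCCCCN(C)C(=O)Cn1cc(Cc2cnc(=O)n(CC(=O)NCCC)c2)c(=O)nc1SCc1ccc(F)cc1` differs from compound 2 by propylcarbamoyl in place of hydroxymethyl on a saturated chain carbon bound to an aromatic nitrogen. Among the compounds with values here, no measured step covers this exchange of one donor-acceptor group for another, so the change is expected to be a number 6 percentage points lower from compound 2 to compound 3 (within the scatter), within the scatter. Compound 3 is therefore estimated at 30%, with a range from 5% to 60%.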

Compound 3, a percentage reported as inhibition, at one concentration (the size of the read-out at that concentration, not a potency): 16%
For compound 3 the middle estimate is 14 percentage points above the measured one; measured number inside the range.
By their numbers in this assay, from the lowest: compound 1; then compound 3; then compound 2.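

In this assay, propylcarbamoyl in place of hydroxymethyl gives a number 20 percentage points lower from compound 2 to compound 3 (beyond the scatter), so the gain at this saturated chain carbon bound to an aromatic nitrogen is not kept in full when the hydroxy end is exchanged. Propylcarbamoyl in place of methyl gives a number 11 percentage points higher from compound 1 to compound 3 (beyond the scatter), which places this group above the ethyl compound but below the 2-hydroxyethyl compound. No measurement here accounts for this order.

Open, on these data alone, is whether the propyl part or the amide itself sets the lower number. A plain carbamoyl, a carboxylic acid or an amine on this chain could separate the two.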